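The compounds below may be only part of what the source reports. "The series", "measured", "known", "first", "only" and "open" are said of these compounds alone.

The step followed here runs from compound 1 to compound 4 in an ADME assay on BHK cells (Mesocricetus auratus) for cytotoxicity, read by MTT assay, with a stated time of 96 h; on this read-out higher numbers stand for lower toxicity in this test and lower numbers for higher toxicity in this test. Compound 1 `C=C(C)CNC(=S)Nc1cccc(C(F)(F)F)c1` is the starting point. In this assay compound 1 gives > 100000 nM, which is a limit of the assay and not a number, as recorded in the limit of > 100000 nM in this assay, at which 1 of the 3 values shown sits. Two further compounds with the same core have been measured: compound 2 `O=[N+]([O-])c1ccc(NC(=S)Nc2cccc(C(F)(F)F)c2)cc1` gives 9500 nM in this assay, and compound 3 `Fc1ccc(NC(=S)Nc2cccc(C(F)(F)F)c2)cc1Cl` gives 10000 nM in this assay. Compound 1 therefore stands at the upper limit of what this assay reports, while compound 2 and compound 3 return numbers well inside the measured range.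

Compound 4 `CC(=O)NC(=S)Nc1cccc(C(F)(F)F)c1` has not been measured. It differs from compound 1 by acetyl in place of 2-methylprop-2-en-1-yl on an amide-type nitrogen; cut one bond further out, the change reads (2-methylprop-2-en-1-yl)amino to acetamido. Within the data shown here, no step between two measured compounds is available to guide this change, so the expectation rests on compound 1 alone, whose own value is only a limit. The step from compound 1 to compound 4 is expected to be small, if any, at an at least 1.1-fold lower number from compound 1 to compound 4 (0.04 log units; that floor lies within the scatter), with compound 4 expected to remain of low toxicity in this assay. Compound 4 is estimated at 90000 nM in this assay, with a range from 25000 nM to 300000 nM.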

Compound 4, half-maximal cytotoxic concentration: > 100000 nM
Compound 4: no number, only a limit (the forecaster's own chance of this, stated with the estimate: 55%); middle value at least 1.1-fold (0.04 log units) from the limit.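

Compound 1 and compound 4 both return a limit of the assay and not a number, so no step between them can be read: the limit of > 100000 nM in this assay, at which 2 of the 4 values shown sit.

The compounds shown leave open whether acetyl in place of 2-methylprop-2-en-1-yl shifts the read-out at all, and by how much.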